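Hydrogen for methyl on compound 2

The source may hold more compounds than are shown below. What is called first, only, known or untested is meant among the compounds shown, and "the series" means these compounds.

Among the compounds with values here, in a functional assay on HCT-116 cells (Homo sapiens) for antiproliferative activity, read by sulforhodamine B assay, with a stated time of 48 h (on this read-out higher numbers stand for weaker inhibition of growth and lower numbers for stronger inhibition of growth), compound 2 (`Cc1c(CN(C)C)c2ccccc2n1S(=O)(=O)c1cccc(/C=C/C(=O)NO)c1`) gives 500 nM as the only number so far. Compound 1 (`Cc1c(CN(C)C)c2ccccc2n1Cc1ccc(C(=O)NO)cc1`) gives > 5000 nM as a limit and not a number. Compound 3 (`CN(C)Cc1cn(S(=O)(=O)c2cccc(/C=C/C(=O)NO)c2)c2ccccc12`) differs from compound 2 by one change, hydrogen in place of methyl on an aromatic carbon with hydrogen in place of methyl on an aromatic carbon. Within the data shown here, no measured pair isolates this change, so no step beyond the usual scatter is expected in this assay in either direction. The expected 1.1-fold lower number from compound 2 to compound 3 (0.05 log units; within the scatter) is therefore small. For compound 3 the estimated value is 450 nM (range 150 nM to 1500 nM).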

Compound 3, concentration for 50% growth inhibition: 540 nM
For compound 3 the middle estimate is 1.2-fold (0.08 log units) below the measured one; the range from low to high includes it.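

In this assay, hydrogen in place of methyl on the aromatic carbon next to the ring nitrogen gives a 1.1-fold higher number from compound 2 to compound 3 (0.03 log units; within the scatter). Within the data shown here, this is the first pair that isolates one change, and it shows that the methyl is not required for the growth inhibition read here. Nothing measured here bears on a cause for this step.

Going by these compounds, whether ethyl, phenyl or an aminomethyl group at this carbon would keep the same level stays open. Among these compounds, compound 1 differs from the others in more than one place, so no step to it can be read.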